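Extending the Alkyne of Compound 1 with a Pyridyl Group

The compounds below may be only part of what the source reports. "The series", "measured", "known", "first", "only" and "open" are said of these compounds alone.

Compound 1 `C#Cc1ccc2ncn(-c3ccnc(N)n3)c2c1` is the strongest of the three measured compounds in an assay on Sf9 cells for inhibition of mitogen-activated protein kinase kinase kinase 14 variant S549D (Homo sapiens), with a stated time of 30 min, in the presence of a further agent that is not named here (a higher number here means a weaker inhibitor, a lower number a stronger inhibitor), where compound 1 gives 251 nM. Its two measured relatives replace the ethynyl group with longer, flexible chains: compound 2 `C=CC(=O)NCCCc1ccc2ncn(-c3ccnc(N)n3)c2c1` gives 501000 nM and compound 3 `CC(=O)NCCCCc1ccc2ncn(-c3ccnc(N)n3)c2c1` gives 398000 nM in this assay. Both changes cost heavily, with a 2000-fold higher number from compound 1 to compound 2 (3.30 log units; beyond the scatter) and a 1600-fold higher number from compound 1 to compound 3 (3.20 log units; beyond the scatter), while the step between the two chains, a 1.3-fold lower number from compound 2 to compound 3 (0.10 log units; within the scatter), is not distinguishable from noise.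

Compound 4 `C#Cc1cccc(C#Cc2ccc3ncn(-c4ccnc(N)n4)c3c2)n1` keeps the ethynyl group intact and instead grows it outward: a group of 8 heavy atoms (7 carbon, 1 nitrogen; one six-membered aromatic ring with 1 hetero atom) in place of a hydrogen atom, on a triple-bonded carbon. For the measured compounds named here, no measured step reports on this kind of extension; the two large losses from compound 1 came from removing the triple bond and replacing it with a saturated chain bearing an amide, which compound 4 does not do. The new group is itself rigid and linear, so the change to the shape near the core is modest compared with the steps to compound 2 and compound 3. The expected step is therefore small, a 2.0-fold higher number from compound 1 to compound 4 (0.30 log units; within the scatter), plausibly within the scatter and with no firm direction. For compound 4 the expected value in this assay is 500 nM, with a range from 80 nM to 4000 nM.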

Compound 4, half-maximal inhibitory concentration: 3160 nM
Compound 4: middle estimate off by 6.3-fold (0.80 log units), on the low side; the measured number falls inside the stated range.
By their numbers in this assay, from the lowest: compound 1; then compound 4; then compounds 3 and 2 (each within the scatter of the next).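

Until now every change had removed the triple bond, so the heavy losses could have been blamed on that removal alone, but compound 4 keeps the triple bond and still loses ground. In this assay, putting the group of 8 heavy atoms in place of the hydrogen atom on the triple-bonded carbon gives a 13-fold higher number from compound 1 to compound 4 (1.10 log units; beyond the scatter), so this position does not accept that group without a clear cost, even though the triple bond itself stays in place. The printed numbers also show that activity survives better here than with the saturated amide chains: compound 4 gives 3160 nM, while compound 3 gives 398000 nM.

Nothing measured here explains why the new group costs activity. Going by these compounds, it remains open whether the loss belongs to the whole group, to its ring nitrogen or to its second ethynyl, and whether a methyl group or a plain phenyl ring on the same triple-bonded carbon would keep the activity of compound 1 or lose it as well.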